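Swapping methoxy for isopropylamino on compound 3

The source may report more compounds than this note shows. Statements on the series, on what has been measured and on what is new or still open speak of the compounds shown alone.

Among the measured compounds shown here, in a physicochemical assay for solubility, read by chemiluminescence, measured as kinetic solubility (on this read-out lower numbers stand for lower solubility and higher numbers for higher solubility), compound 3 `COc1nc(NS(=O)(=O)c2cccc(Cl)c2Cl)c2c(OC)nn(C)c2n1` gives 148000 nM, the lower of the two actual numbers so far. Compound 1 `COc1nn(C(C)C)c2ncnc(NS(=O)(=O)c3cccc(Cl)c3Cl)c12` gives 404000 nM, a gap beyond the scatter. Compound 2 `COc1nn(CC(N)=O)c2ncnc(NS(=O)(=O)c3cccc(Cl)c3Cl)c12` gives >= 490000 nM, which is a limit of the assay and not a number. Compound 4 `COc1nn(C)c2nc(NC(C)C)nc(NS(=O)(=O)c3cccc(Cl)c3Cl)c12` carries isopropylamino in place of methoxy on an aromatic carbon, between two ring nitrogen atoms (isopropylamino in place of methoxy on an aromatic carbon). For the measured compounds named here, the only measured step, an at least 1.2-fold higher number from compound 1 to compound 2 (0.08 log units; that floor lies within the scatter), changes a group on an aromatic nitrogen, so it offers little guidance for this different site. The estimated step is a 1.2-fold lower number from compound 3 to compound 4 (0.09 log units; within the scatter), with none expected beyond the scatter. In this assay the estimate for compound 4 is 120000 nM, expected between 40000 nM and 350000 nM.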

Compound 4, solubility: >= 551000 nM
Compound 4 gave a limit, no number (the forecaster's own chance of this, stated with the estimate: 5%); middle value at least 4.5-fold (0.66 log units) from the limit.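

In this assay, among the compounds shown here, the earlier compounds changed only a group on an aromatic nitrogen, whereas here the aromatic carbon between two ring nitrogen atoms is changed, giving an at least 3.7-fold higher number from compound 3 to compound 4 (0.57 log units; beyond the scatter). So this position can move the read-out beyond the scatter, with isopropylamino giving the higher number. Compound 4 gives a limit of the assay and not a number, so the step has a floor but no known size: the limit of >= 551000 nM in this assay, at which 1 of the 4 values shown sits.

Going by these compounds, it remains open whether a smaller amine such as methylamino, or a carboxylic acid, on this carbon would shift the read-out likewise.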